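The source may report more compounds than this note shows. Statements on the series, on what has been measured and on what is new or still open speak of the compounds shown alone.

Measured compounds in a functional assay on L02 cells (Homo sapiens) for inhibition, read by MTT assay, with a stated time of 48 h; a higher number here means a weaker inhibitor, a lower number a stronger inhibitor:
compound 1 `O=C(/C=C/c1coc2cc(O)ccc2c1=O)NCc1ccc(F)cc1` — in this assay compound 1 gives > 200000 nM, which is a limit of the assay rather than a number.
compound 2 `COc1ccc2c(=O)c(/C=C/C(=O)NCc3ccc(F)cc3)coc2c1` — in this assay compound 2 gives > 200000 nM, again a limit of the assay.
compound 3 `O=C(/C=C/c1coc2cc(O)ccc2c1=O)Nc1ccccc1` — in this assay compound 3 gives > 200000 nM, also a limit of the assay.

Compound 2 therefore stands at the edge of what this assay can report: its value is a limit, and the two other values shown sit at the same limit, as summed up by the limit of > 200000 nM in this assay, at which 3 of the 3 values shown sit. The step from compound 1 to compound 2 (a step that the two limits leave unreadable from compound 1 to compound 2) and the step from compound 1 to compound 3 (a step that the two limits leave unreadable from compound 1 to compound 3) are both unreadable, since each joins two limits.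

The next compound is compound 4 `COc1ccc(NC(=O)/C=C/c2coc3cc(OC)ccc3c2=O)cc1`. Its difference from compound 2 is 4-methoxyphenyl in place of 4-fluorobenzyl on an amide-type nitrogen. Among the compounds with values here, the only measured step touching the same amide-type nitrogen, from compound 1 to compound 3, gives no size, so no measured step sets an expectation for a change in this assay beyond the scatter, in either direction.

With every shown value at the limit, compound 4 is expected to give about 200000 nM in this assay, most likely reported as a limit, with a range of 80000 nM to 500000 nM. The step from compound 2 to compound 4 is thus expected to be a number no higher from compound 2 to compound 4 (the limit leaves the size open).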

Compound 4, half-maximal inhibitory concentration: > 200000 nM
Compound 4: a limit, no number; the forecaster's own chance of this, stated with the estimate: 85%; the middle value sits exactly at the limit.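

In this assay compound 4 gives > 200000 nM, which is a limit of the assay and not a number. Compound 2 also sits at a limit, so the size of the step between compound 2 and compound 4 cannot be read. The compounds shown leave open which change, if any, would give a measurable value, because all of them sit at the same edge: the limit of > 200000 nM in this assay, at which 4 of the 4 values shown sit.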